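Trimethoxyphenyl series: tert-butylphenyl replaces methylphenyl

The compounds below may be only part of what the source reports. "The series", "measured", "known", "first", "only" and "open" are said of these compounds alone.

Measured compounds in a functional assay on MCF7 cells (Homo sapiens) for inhibition, read by CCK-8 assay, with a stated time of 48 h; a higher number here means a weaker inhibitor, a lower number a stronger inhibitor:
compound 1 `COc1cc(-c2ccnc3cc(-c4c[nH]c5ccccc45)nn23)cc(OC)c1OC`, 85 nM
compound 2 `COc1cc(-c2ccnc3cc(-c4cccc(C)c4)nn23)cc(OC)c1OC`, 1080 nM

Among the compounds with values here, compound 2 gives the higher of the two numbers so far in this assay; its nearest neighbour is compound 1, and the change was a 13-fold higher number from compound 1 to compound 2 (1.10 log units; beyond the scatter). Compound 3 `COc1cc(-c2ccnc3cc(-c4ccc(C(C)(C)C)cc4)nn23)cc(OC)c1OC` keeps the shared core of compound 2 and differs in one place: 4-(tert-butyl)phenyl in place of 3-methylphenyl on an aromatic carbon. Within the data shown here, no measured step compares two single-ring aryl groups against each other; the only step known, from an 1H-indol-3-yl to a 3-methylphenyl, describes a different kind of change and so bears only loosely on this one. On that basis compound 3 is expected to stay near compound 2, with a step of a 1.4-fold higher number from compound 2 to compound 3 (0.14 log units; within the scatter), no larger than the usual scatter. The estimate for compound 3 in this assay is 1500 nM, with a range from 500 nM to 4500 nM.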

Compound 3, half-maximal inhibitory concentration: > 10000 nM
Compound 3: a limit, no number; the forecaster's own chance of this, stated with the estimate: 5%; middle value at least 6.6-fold (0.82 log units) from the limit.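

In this assay compound 3 gives a limit of the assay and not a number: the limit of > 10000 nM in this assay, at which 1 of the 3 values shown sits.

Within the data shown here, this position, on an aromatic carbon of a five-membered aromatic ring with 2 nitrogen, had so far been seen to respond only to the loss of 1H-indol-3-yl, but it also responds to a change from one single-ring aryl group to another, with an at least 9.2-fold higher number from compound 2 to compound 3 (0.96 log units; beyond the scatter). Measured against the 1H-indol-3-yl group, 4-(tert-butyl)phenyl gives an at least 110-fold higher number from compound 1 to compound 3 (2.07 log units; beyond the scatter), so it moves the number further than 3-methylphenyl does.

The step from 3-methylphenyl to 4-(tert-butyl)phenyl changes both the group on the phenyl ring and where it sits, and the compounds shown do not separate the two. From the compounds shown here alone, whether 4-methylphenyl, or a phenyl ring carrying an amine, would read nearer compound 1 or compound 3 stays open.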